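A phenoxy group takes the place of cyclohexyl

The source may report more compounds than this note shows. Statements on the series, on what has been measured and on what is new or still open speak of the compounds shown alone.

In a functional assay on brain (Rattus norvegicus, strain Wistar) for inhibition (on this read-out lower numbers stand for stronger inhibition and higher numbers for weaker inhibition), compound 1 `Cc1ccc(-c2c(C)[nH]c(=O)n2C)cc1` gives 85300 nM and compound 2 `COc1ccc(-c2c(C)[nH]c(=O)n2C)cc1` gives 147000 nM. The step between them, a 1.7-fold higher number from compound 1 to compound 2 (0.24 log units; within the scatter), shows that methoxy in place of methyl makes no difference that can be told from these data. Compound 3 `Cc1[nH]c(=O)n(C)c1-c1ccc(C2CCCCC2)cc1`, which carries cyclohexyl, gives 10000 nM, the lowest number of the three and thus the strongest inhibition in this small set. It stands clear of both others, with an 8.5-fold lower number from compound 1 to compound 3 (0.93 log units; beyond the scatter) and a 15-fold lower number from compound 2 to compound 3 (1.17 log units; beyond the scatter), each beyond the scatter.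

The next compound is compound 4 `Cc1[nH]c(=O)n(C)c1-c1ccc(Oc2ccccc2)cc1`, still unmeasured, with phenoxy in place of cyclohexyl on an aromatic carbon. Among the measured compounds shown here, no measured step exchanges one ring-bearing group for another, so the evidence is indirect. For the measured compounds named here, the two steps into compound 3 show only that cyclohexyl gave lower numbers than methyl or methoxy. Phenoxy also brings a six-membered ring to that place, so compound 4 is expected to stay nearer compound 3 than compound 1 or compound 2, though some loss remains possible. The expected change is small, a 1.2-fold higher number from compound 3 to compound 4 (0.08 log units; within the scatter), and not beyond the scatter. For compound 4 the estimated value is 12000 nM, with an expected range from 3500 nM to 40000 nM.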

Compound 4, half-maximal inhibitory concentration: 8100 nM
The estimate for compound 4 lay 1.5-fold (0.17 log units) above the measured number; the range from low to high includes it.
By their numbers in this assay, from the lowest: compounds 4 and 3 (each within the scatter of the next); then compounds 1 and 2 (each within the scatter of the next).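

In this assay the exchange of cyclohexyl for phenoxy gives a 1.2-fold lower number from compound 3 to compound 4 (0.09 log units; within the scatter) and so cannot be told apart from no change, even though the non-aromatic carbon ring gives way to an aromatic one and an oxygen now joins that ring to the rest of the molecule. Among the compounds shown here, this position therefore tolerates this change in ring type and the added oxygen, something that the earlier compounds, with only cyclohexyl as a ring-bearing group, could not show. Phenoxy also stands clear of the two smaller groups, with an 11-fold lower number from compound 1 to compound 4 (1.02 log units; beyond the scatter) and an 18-fold lower number from compound 2 to compound 4 (1.26 log units; beyond the scatter) both beyond the scatter, so that among these four compounds both ring-bearing groups give lower numbers than methyl or methoxy, and no compound goes against this; nothing shown here gives a reason for these numbers.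

The compounds shown leave open whether a ring is needed at this place at all or whether a longer chain such as hexyl would read the same, and how a ring holding an amine, such as piperidinyl, would compare. They also leave open what a carboxylic acid on the outer ring of phenoxy would do, and whether a larger group on the core in place of its methyl would change these numbers.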